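The source may report more compounds than this note shows. Statements on the series, on what has been measured and on what is new or still open speak of the compounds shown alone.

Of the compounds shown here, three sharing one core have been tested in an ADME assay on MT4 cells (Homo sapiens) for cytotoxicity, read by MTT assay, with a stated time of 4 days; on this read-out lower numbers stand for higher toxicity in this test and higher numbers for lower toxicity in this test. Compound 1 `Cc1ccc(-c2c(C)c(-c3ccc(C)c(C)c3)c(C(OC(C)(C)C)C(=O)O)c(C)c2N)cc1C` carries a hydrogen on a nitrogen on an aromatic ring and gives 12000 nM. Compound 2 `Cc1ccc(-c2c(C)c(-c3ccc(C)c(C)c3)c(C(OC(C)(C)C)C(=O)O)c(C)c2NS(=O)(=O)c2ccccc2)cc1C` carries a phenylsulfonyl there and gives 11000 nM. Compound 3 `CCC(=O)Nc1c(C)c(C(OC(C)(C)C)C(=O)O)c(-c2ccc(C)c(C)c2)c(C)c1-c1ccc(C)c(C)c1` carries a propanoyl there and gives 15000 nM. Compound 3 has the largest of the three numbers, yet the steps leading to it are small: a 1.3-fold higher number from compound 1 to compound 3 (0.10 log units; within the scatter) and a 1.4-fold higher number from compound 2 to compound 3 (0.13 log units; within the scatter), both within the scatter, as is a 1.1-fold lower number from compound 1 to compound 2 (0.04 log units; within the scatter).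

Compound 4 `Cc1ccc(-c2c(C)c(-c3ccc(C)c(C)c3)c(C(OC(C)(C)C)C(=O)O)c(C)c2NCc2ccccc2)cc1C` differs from compound 3 only at that nitrogen: benzyl in place of propanoyl on a nitrogen on an aromatic ring. The two steps that bear on this change are those at the same nitrogen, from compound 1 and from compound 2 to compound 3, and neither reached beyond the scatter. A fourth substituent at this position is therefore expected to bring no step beyond the scatter, giving an expected 1.2-fold lower number from compound 3 to compound 4 (0.06 log units; within the scatter).

For compound 4 the expected value in this assay is 13000 nM, with a range from 6000 nM to 28000 nM.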

Compound 4, half-maximal cytotoxic concentration: 4000 nM
Compound 4: middle estimate off by 3.3-fold (0.51 log units), on the high side; measured number outside the range, below it.
By their numbers in this assay, from the lowest: compound 4; then compounds 2, 1 and 3 (each within the scatter of the next).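

In this assay this nitrogen proves sensitive to what it carries: benzyl gives a 3.8-fold lower number from compound 3 to compound 4 (0.57 log units; beyond the scatter) and also a 2.8-fold lower number from compound 2 to compound 4 (0.44 log units; beyond the scatter) and a 3.0-fold lower number from compound 1 to compound 4 (0.48 log units; beyond the scatter) at the same place. Hydrogen, phenylsulfonyl and propanoyl had stayed within the scatter of one another, so compound 4 is the first to stand apart, on the side of higher toxicity in this test. An aromatic ring in the group is not enough to produce this, as compound 2 goes against that reading: its phenylsulfonyl also holds such a ring, yet it stays within the scatter of compounds 1 and 3.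

From the compounds shown here alone, whether a plain ethyl on this nitrogen, or a longer chain ending in a phenyl ring, would behave like benzyl remains open. Nothing at hand explains the benzyl result.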